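A few compounds are considered here, and "the series" means these few. Any claim that something is new, unique, unknown or untested is made for them only; others in the source may bear on it.

Compound 1 `O=C1C(Nc2ccc(I)cc2)=CC(=O)c2c1nc1n2[C@H]2OC[C@@H](O)[C@H]2OC1` carries an iodo-substituted anilino group on the shared core. In a functional assay on MGC-803 cells (Homo sapiens) for inhibition, read by sulforhodamine B assay (on this read-out lower numbers stand for stronger inhibition and higher numbers for weaker inhibition), compound 1 gives 2150 nM, the highest of the two numbers recorded. Compound 2 `O=C1C=C(Nc2ccccc2)C(=O)c2c1nc1n2[C@H]2OC[C@@H](O)[C@H]2OC1` gives 1730 nM in this assay, within the scatter of compound 1. Compound 3 `O=C1C=C(N2CCCCC2)C(=O)c2c1nc1n2[C@H]2OC[C@@H](O)[C@H]2OC1` reaches only > 8000 nM in this assay, which is a limit rather than a number. Among the measured compounds shown here, the single measured step, an at least 4.6-fold higher number from compound 2 to compound 3 (0.66 log units; beyond the scatter), concerns the anilino group itself rather than a substituent on its ring. Compound 4 `CCCc1ccc(NC2=CC(=O)c3c(nc4n3[C@H]3OC[C@@H](O)[C@H]3OC4)C2=O)cc1` differs from compound 1 by propyl in place of iodo on an aromatic carbon. That compound 1 at 2150 nM and compound 2 at 1730 nM sit within the scatter of each other suggests a change at this position carries little weight, so a step of a 1.1-fold lower number from compound 1 to compound 4 (0.03 log units; within the scatter) is expected. Compound 4 is estimated at 2000 nM, between 900 nM and 5000 nM.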

Compound 4, half-maximal inhibitory concentration: 1920 nM
Compound 4: middle estimate off by 1.0-fold (0.02 log units), on the high side, within the range that was stated.
By their numbers in this assay, from the lowest: compounds 2, 4 and 1 (each within the scatter of the next). At a limit, above all of these: compound 3.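

In this assay, the exchange of iodo for propyl gives a 1.1-fold lower number from compound 1 to compound 4 (0.05 log units; within the scatter). The earlier compounds shown here compared iodo only with an unsubstituted ring, whereas this step shows that a carbon chain on this aromatic carbon also stays within the scatter, so three different ends of the anilino ring now read alike. No measurement shown gives a reason for this. From the compounds shown here alone, whether an amine, a carboxylic acid or a longer chain at this position would also stay within the scatter remains open.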